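The source may hold more compounds than are shown below. What is called first, only, known or untested is meant among the compounds shown, and "the series" means these compounds.

Three compounds have been measured in a functional assay on HCT-15 cells (Homo sapiens) for cytotoxicity, read by CCK-8 assay; on this read-out higher numbers stand for weaker inhibition and lower numbers for stronger inhibition:

Compound 1, `Oc1cccc(-c2cc(-c3cccs3)cc(-c3ccccc3O)n2)c1`, gives > 50000 nM, a limit of the assay rather than a number.
Compound 2, `Oc1ccc(-c2cc(-c3cccs3)cc(-c3ccccc3O)n2)cc1`, gives > 50000 nM, again a limit of the assay rather than a number.
Compound 3, `Oc1ccc(-c2cc(-c3ccco3)cc(-c3cccc(O)c3)n2)cc1`, gives 840 nM.

Going by the values given here, compound 3 thus supplies the only number here; the two others sit at the limit of > 50000 nM in this assay, at which 2 of the 3 values shown sit. Compound 1 and compound 2 share a core and differ by one change, (4-hydroxyphenyl in place of 3-hydroxyphenyl on an aromatic carbon). Because both sit at the limit of > 50000 nM in this assay, at which 2 of the 3 values shown sit, the step that the two limits leave unreadable from compound 1 to compound 2 cannot be read. The core of compound 3 differs from that of compound 1 in more than one place, and the difference between the two cores is not broken down here.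

Compound 4, `Oc1ccc(-c2cc(-c3ccco3)cc(-c3ccc(O)cc3)n2)cc1`, has not yet been measured. It arises from compound 3 by 4-hydroxyphenyl in place of 3-hydroxyphenyl on an aromatic carbon. Among the compounds with values here, this is the same kind of change as the one from compound 1 to compound 2, not the same: in compound 1 the changed group sits meta to a 2-hydroxyphenyl group and meta to a thiophen-2-yl group, whereas in compound 3 it sits meta to a 4-hydroxyphenyl group and meta to a furan-2-yl group. The earlier instance gives no readable size, so nothing measured tells how large the step in this assay should be. The step expected here is a 1.2-fold higher number from compound 3 to compound 4 (0.08 log units; within the scatter), small, with nothing pointing to a large effect. Compound 4 is therefore estimated at 1000 nM, most likely between 300 nM and 5000 nM.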

Compound 4, half-maximal inhibitory concentration: 14000 nM
Estimate against measurement, compound 4: 14-fold (1.15 log units) below, outside the stated range (above it).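

In this assay, 4-hydroxyphenyl in place of 3-hydroxyphenyl gives a 17-fold higher number from compound 3 to compound 4 (1.22 log units; beyond the scatter), so on this core the change clearly weakens inhibition, by more than the usual scatter of repeated measurements. The same change on the core of compound 1 offers no size to compare with this one, because compound 1 and compound 2 both stand at a limit of the assay and not at a number: the limit of > 50000 nM in this assay, at which 2 of the 4 values shown sit. This leaves a single readable instance of the change, which shows that the swap can matter a great deal on one core but does not show whether a step of this size carries over to another core, and nothing shown explains why the step is so large here.

The compounds shown leave open whether furan-2-yl and thiophen-2-yl can be exchanged with nothing else altered, and how a 2-hydroxyphenyl group would behave on the core of compound 3. They also leave open what would happen if an amine or a carboxylic acid took the place of the hydroxyl on the 3-hydroxyphenyl group of compound 3.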